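The source may hold more compounds than are shown below. What is called first, only, known or untested is meant among the compounds shown, and "the series" means these compounds.

Measured so far in an in vitro ADME assay on microsomes from liver (Mus musculus) for pharmacokinetics; on this read-out higher numbers stand for fast clearance and lower numbers for slow clearance:
- compound 1 `O=C(NC1CC1)c1ccc(CN([C@@H]2CC(F)(F)CCNC2=O)S(=O)(=O)c2ccc(Cl)cc2)cc1`: 2.2 mL.min-1.g-1
- compound 2 `CC(C)C1CCNC(=O)C(N(Cc2ccc(C(=O)NC3CC3)cc2)S(=O)(=O)c2ccc(Cl)cc2)C1`: 203 mL.min-1.g-1
- compound 3 `O=C(NC1CC1)c1ccc(CN(C2CC(C(F)(F)F)CCNC2=O)S(=O)(=O)c2ccc(Cl)cc2)cc1`: 39 mL.min-1.g-1

Compound 3 holds the second highest of the three numbers in this assay. It lies nearer the top of the set, as a 5.2-fold lower number from compound 2 to compound 3 (0.72 log units; beyond the scatter) is smaller than an 18-fold higher number from compound 1 to compound 3 (1.25 log units; beyond the scatter).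

Compound 4 `CC1(C)CCNC(=O)C(N(Cc2ccc(C(=O)NC3CC3)cc2)S(=O)(=O)c2ccc(Cl)cc2)C1` is the next case, with the change (5,5-dimethyl-2-oxoazepan-3-yl in place of 2-oxo-5-(trifluoromethyl)azepan-3-yl on a sulfonamide nitrogen). In words, this is 5,5-dimethyl-2-oxoazepan-3-yl in place of 2-oxo-5-(trifluoromethyl)azepan-3-yl on a sulfonamide nitrogen.

Among the measured compounds shown here, no measured compound carries this group, so the evidence is indirect. The step of a 5.2-fold lower number from compound 2 to compound 3 (0.72 log units; beyond the scatter) shows a modest drop when trifluoromethyl replaces isopropyl, which suggests that losing trifluoromethyl for a group without fluorine may raise the number. The large step of a 92-fold higher number from compound 1 to compound 2 (1.97 log units; beyond the scatter) points the same way. Against a full rise to the level of compound 2, the substitution pattern of compound 4 matches that of compound 1, which has the lowest number at 2.2 mL.min-1.g-1.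

A small upward move is therefore expected, estimated as a 1.8-fold higher number from compound 3 to compound 4 (0.25 log units; within the scatter), and it may stay within the scatter. For compound 4 the estimated value is 70 mL.min-1.g-1, with an expected range of 20 mL.min-1.g-1 to 200 mL.min-1.g-1.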

Compound 4, intrinsic clearance in microsomes: 191 mL.min-1.g-1
For compound 4 the middle estimate is 2.7-fold (0.44 log units) below the measured one; the measured number falls inside the stated range.
By their numbers in this assay, from the lowest: compound 1; then compound 3; then compounds 4 and 2 (each within the scatter of the next).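

In this assay the 5,5-dimethyl-2-oxoazepan-3-yl group on the sulfonamide nitrogen gives a 4.9-fold higher number from compound 3 to compound 4 (0.69 log units; beyond the scatter) when it replaces 2-oxo-5-(trifluoromethyl)azepan-3-yl and an 87-fold higher number from compound 1 to compound 4 (1.94 log units; beyond the scatter) when it replaces 5,5-difluoro-2-oxoazepan-3-yl, so the substitution pattern shared by compound 1 and compound 4 does not by itself keep the number low. Among the compounds shown here, the step of a 1.1-fold lower number from compound 2 to compound 4 (0.03 log units; within the scatter) for replacing 5-isopropyl-2-oxoazepan-3-yl places compound 2 and compound 4 level with each other, and across these four compounds the two groups without fluorine give the high numbers, while the two with fluorine give lower numbers, with no compound going against this. Nothing measured here explains that split.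

From the compounds shown here alone, whether fluorine itself decides the number stays open, as does how a hydroxyl, a methoxy, a nitrile or an amine on the same ring carbon would read in this assay on this series. Compound 1 is drawn as a single stereoisomer and the other three are drawn without stereochemistry, so any contribution of configuration to these differences also remains unresolved.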